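The source may report more compounds than this note shows. Statements on the series, on what has been measured and on what is new or still open speak of the compounds shown alone.

Working notes on a small set of guanidines in an assay on membranes from brain (Cavia porcellus) for binding affinity to Sigma non-opioid intracellular receptor 1 (Homo sapiens); a lower number here means a stronger inhibitor, a higher number a weaker inhibitor. Compound 1 `Cc1ccccc1/N=C(/N)Nc1ccccc1[N+](=O)[O-]` gives 113 nM, the second highest of the three numbers. Its nearest neighbour is compound 3 `COc1ccccc1NC(=N)Nc1ccccc1OC` at 2200 nM, a gap beyond the scatter; the furthest is compound 2 `N=C(Nc1ccccc1I)NC1CC2CCC1C2` at 4 nM, again beyond the scatter. Compound 4 `Cc1ccccc1/N=C(/N)Nc1ccccc1I` differs from compound 1 by iodo in place of nitro on an aromatic carbon. For the measured compounds named here, no measured pair shows this change on its own. A step toward a lower number is expected, of moderate size, because compound 2 gives 4 nM while carrying the same iodo group on an aromatic ring. The expected step of a 2.8-fold lower number from compound 1 to compound 4 (0.45 log units; beyond the scatter) should lie beyond the scatter. Compound 4 is estimated at 40 nM, within 10 nM to 160 nM.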

Compound 4, half-maximal inhibitory concentration: 21 nM
Compound 4: middle estimate off by 1.9-fold (0.28 log units), on the high side; measured number inside the range.
By their numbers in this assay, from the lowest: compound 2; then compound 4; then compound 1; then compound 3.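

In this assay, for the compounds shown here, iodo in place of nitro on an aromatic carbon, ortho to a large group, gives a 5.4-fold lower number from compound 1 to compound 4 (0.73 log units; beyond the scatter) on the core of compound 1, the first reading of this change on its own. Nitro carries hydrogen-bond acceptors and iodo carries none, and the group also shrinks, so this single pair cannot separate those differences. No measurement here bears on why the number moves this way. The compounds shown leave open whether chloro or an amine on this aromatic carbon would give a number nearer that of iodo or nitro. They also leave open whether the same change gives a similar step on another core.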